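A few compounds are considered here, and "the series" means these few. Any claim that something is new, unique, unknown or untested is made for them only; others in the source may bear on it.

Compound 1 `CCOC(=O)c1c(C)noc1OCC(=O)[C@H](CC(=O)O)NC(=O)[C@@H](NC(=O)COc1cccc2ccccc12)C(C)C` gives > 200000 nM in a functional assay on Jurkat cells (Homo sapiens) for inhibition (a lower number here means a stronger inhibitor, a higher number a weaker inhibitor), which is a limit of the assay and not a number.
Compound 2 `COC(=O)c1cc(OCC(=O)[C@H](CC(=O)O)NC(=O)[C@@H](NC(=O)COc2cccc3ccccc23)C(C)C)no1` gives 71000 nM in this assay.
Compound 3 `CC(C)[C@H](NC(=O)COc1cccc2ccccc12)C(=O)N[C@@H](CC(=O)O)C(=O)CSc1ncc[nH]1` gives > 200000 nM in this assay, again a limit and not a number.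

Compound 3 thus sits at the limit rather than at a measured number, and compound 1 sits there as well, so those two cannot be placed in any order; the limit of > 200000 nM in this assay, at which 2 of the 3 values shown sit, covers both. Within the data shown here, only compound 2 returns a number, and the step of an at least 2.8-fold higher number from compound 2 to compound 3 (0.44 log units; beyond the scatter) is the one readable step that reaches compound 3, while a step that the two limits leave unreadable from compound 1 to compound 3 cannot be read. Compound 4 `CC(C)[C@H](NC(=O)COc1cccc2ccccc12)C(=O)N[C@@H](CC(=O)O)C(=O)CSc1nccn1C` differs from compound 3 by methyl in place of hydrogen on an aromatic nitrogen. Among the measured compounds shown here, no measured step touches a change of this kind; the two steps that end at compound 3 concern the group on the saturated chain carbon, not the ring nitrogen. What is expected is a number no higher from compound 3 to compound 4 (the limit leaves the size open), and a further limit rather than a number for compound 4 would be the most likely outcome. The estimate for compound 4 is 200000 nM, between 50000 nM and 600000 nM.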

Compound 4, half-maximal inhibitory concentration: > 200000 nM
Compound 4 ended at the assay's limit; the forecaster's own chance of this, stated with the estimate: 70%; the middle value sits exactly at the limit.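

In this assay compound 4 gives > 200000 nM, which is a limit of the assay and not a number. Methyl on the aromatic nitrogen thus does not bring the (1H-imidazol-2-yl)sulfanyl series to a measured number, and the one readable step is an at least 2.8-fold higher number from compound 2 to compound 4 (0.44 log units; beyond the scatter). The steps joining compound 4 to compound 3 and to compound 1 cannot be read, so the size of the methyl change stays unknown, and compound 2 remains the only compound with a number: the limit of > 200000 nM in this assay, at which 3 of the 4 values shown sit.

The compounds shown leave open whether the methyl change has any effect at all in this assay. They also leave open whether an ethyl group on that ring nitrogen, or a carboxylic acid in place of the methyl ester of compound 2, would give a number.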